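The source may hold more compounds than are shown below. What is called first, only, known or untested is meant among the compounds shown, and "the series" means these compounds.

In a functional assay on HeLa cells (Homo sapiens) for antiproliferative activity, read by CCK-8 assay, with a stated time of 72 h (a higher number here means a weaker inhibitor of growth, a lower number a stronger inhibitor of growth), compound 1 (`CC[C@@H]1C(=O)N(C)c2cnc(Nc3ccc(S(=O)(=O)NC)cc3)nc2N1C1CCCC1`) gives 148 nM and compound 3 (`CCCNC(=O)c1ccc2c(ccn2-c2ncc3c(n2)N(C2CCCC2)[C@H](CC)C(=O)N3C)c1`) gives 238 nM. Compound 2 (`CCC1C(=O)N(C)c2cnc(-n3ccc4cc(C(=O)NC)ccc43)nc2N1c1ccn(C)n1`) gives 6330 nM, the highest of the three numbers and beyond the scatter from both others. Compound 4 (`CCCCNC(=O)c1ccc2c(ccn2-c2ncc3c(n2)N(c2ccn(C)n2)C(CC)C(=O)N3C)c1`) differs from compound 2 in one place: propyl in place of hydrogen on a saturated chain carbon bound to an amide-type nitrogen, which reads as methylcarbamoyl becoming butylcarbamoyl. Among the measured compounds shown here, no measured pair shows this change alone. Compound 3, at 238 nM, has a propyl chain on its amide but also differs from compound 2 in another place. A modest move toward a lower number is therefore expected, possibly none beyond the scatter. The estimated change is a 1.8-fold lower number from compound 2 to compound 4 (0.26 log units; within the scatter). For compound 4 the expected value is 3500 nM, within an estimated range of 1200 nM to 10000 nM.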

Compound 4, concentration for 50% growth inhibition: 4260 nM
Compound 4: the middle estimate sits 1.2-fold (0.09 log units) below what was measured; low and high end bracket the measured number.
By their numbers in this assay, from the lowest: compounds 1 and 3 (each within the scatter of the next); then compounds 4 and 2 (each within the scatter of the next).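

In this assay, replacing methylcarbamoyl with butylcarbamoyl gives a 1.5-fold lower number from compound 2 to compound 4 (0.17 log units; within the scatter), so this change on a saturated chain carbon bound to an amide-type nitrogen produces no difference that can be distinguished from the scatter. The earlier compounds shown here could not show this, since no two of them differed in this one place. No measured evidence available here bears on this result.

From the compounds shown here alone, it remains open whether a chain ending in an amine or a carboxylic acid would give a clearly different number at this position.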